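This account rests on a few compounds, and the source may have more. Where it says the series, first, only, none or still open, it means among the compounds named here.

Values so far in a physicochemical assay for lipophilicity (on this read-out higher numbers stand for higher lipophilicity and lower numbers for lower lipophilicity), are:

- compound 1 `Cc1csc2cc([C@H](C)Nc3ncnc(N)c3C#N)c(-c3cccc(CN4CCC(N(C)CC(C)C)CC4)c3)c(=O)n12` gives 1.7
- compound 2 `Cc1csc2cc([C@H](C)Nc3ncnc(N)c3C#N)c(-c3cccc(CC4CCN(C(C)C)CC4)c3)c(=O)n12` gives 1.1

Of these two, compound 2 stands lower, and compound 1 is the nearest and only comparison. The next change leads to compound 3 `Cc1csc2cc([C@H](C)Nc3ncnc(N)c3C#N)c(-c3ccccc3)c(=O)n12` and is hydrogen in place of (1-isopropylpiperidin-4-yl)methyl on an aromatic carbon with hydrogen in place of (1-isopropylpiperidin-4-yl)methyl on an aromatic carbon.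

Among the measured compounds shown here, one measured step bears on this, and only loosely. a number 0.60 log units lower from compound 1 to compound 2 (beyond the scatter) is modest and exchanges one side group for another. For the measured compounds named here, no measured compound lacks the side group, so the data give no direct size for removing it. A rise in this assay is nevertheless expected, larger than that modest step, and this rests on judgement rather than on a measured trend.

The estimated change is a number 1.40 log units higher from compound 2 to compound 3 (beyond the scatter) with wide uncertainty. Compound 3 is estimated at 2.5 (expected range 1.8 to 3.2).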

Compound 3, distribution coefficient: 2.7
Estimate against measurement, compound 3: 0.20 log units below; the range from low to high includes it.
By their numbers in this assay, from the lowest: compound 2; then compound 1; then compound 3.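

Hydrogen in place of (1-isopropylpiperidin-4-yl)methyl gives a number 1.60 log units higher from compound 2 to compound 3 (beyond the scatter) in this assay and so supplies the first reading at this aromatic carbon without a side group. The earlier exchange of one side group for another, a number 0.60 log units lower from compound 1 to compound 2 (beyond the scatter) and rated modest, moved the number by much less, so on this read-out removing the side group counts for more here than that swap did. Nothing at hand accounts for the size of this step.

Still open, going by these compounds, is how much of the step belongs to the ring nitrogen and how much to the carbon count, which a cyclohexylmethyl group at the same carbon would help to separate. Also open, on these data alone, is where a small group such as methyl or aminomethyl would fall in this assay on this core.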